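Naphthyl for trifluoromethylphenyl on a urea nitrogen

The source may hold more compounds than are shown below. What is called first, only, known or untested is meant among the compounds shown, and "the series" means these compounds.

Three ureas sharing one core have been measured in an assay on isolated protein for inhibition of serine/threonine-protein kinase PLK1 (Homo sapiens), read by radiometric assay and 33P incorporation, with a stated time of 40 min, tested at 20 uM, in the presence of a further agent that is not named here; on this read-out lower numbers stand for less inhibition and higher numbers for more inhibition at the one concentration tested (going by the name of the read-out). Compound 3 `CCNc1cc(-c2ccc(NC(=O)Nc3ccc(C(F)(F)F)cc3)cc2C)ccn1` gives 54.8%. Compound 1 `CCNc1cc(-c2ccc(NC(=O)Nc3ccc(C)cc3)cc2C)ccn1` gives 47.5%, and compound 2 `CCNc1cc(-c2ccc(NC(=O)Nc3ccc(OC)cc3)cc2C)ccn1` gives 45.8%; no two of the three numbers are separated by more than the scatter, so compound 3 cannot be said to give a higher number than the other two. Compound 4 `CCNc1cc(-c2ccc(NC(=O)Nc3cccc4ccccc34)cc2C)ccn1` differs from compound 3 by naphthalen-1-yl in place of 4-(trifluoromethyl)phenyl on an amide-type nitrogen. Within the data shown here, the steps that bear on this change, a number 7.3 percentage points higher from compound 1 to compound 3 (within the scatter) and a number 9 percentage points higher from compound 2 to compound 3 (within the scatter), both altered only a substituent on the same aryl ring and stayed within the scatter, so no step beyond the scatter is expected in this assay here either. Compound 4 is therefore estimated at 50%, within 30% to 70%, an expected step of a number 4.8 percentage points lower from compound 3 to compound 4 (within the scatter).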

Compound 4, a percentage reported as inhibition, at one concentration (the size of the read-out at that concentration, not a potency): 35.3%
Beside the measured number, compound 4's estimate is 14.7 percentage points above it; the range from low to high includes it.
By their numbers in this assay, from the lowest: compound 4; then compounds 2, 1 and 3 (each within the scatter of the next).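

In this assay, changing the whole aryl group on the amide-type nitrogen moved the number beyond the scatter, which no substituent change among compound 1, compound 2 and compound 3 had done. Naphthalen-1-yl lowers the number against all three (a number 19.5 percentage points lower from compound 3 to compound 4 (beyond the scatter); a number 10.5 percentage points lower from compound 2 to compound 4 (beyond the scatter); a number 12.2 percentage points lower from compound 1 to compound 4 (beyond the scatter)), leaving compound 4 lowest of the four. Nothing available explains this drop.

As far as these compounds go, whether it follows from the second aromatic ring or from its mode of attachment remains open. Naphthalen-2-yl or cyclohexyl on this nitrogen could help separate those readings.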